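The source may report more compounds than this note shows. Statements on the series, on what has been measured and on what is new or still open speak of the compounds shown alone.

Working notes on the series, read in a functional assay on HUVEC cells (Homo sapiens); a lower number here means that less compound is needed, a higher number that more compound is needed for the effect. Compound 1 `COC1=C(C)C(=O)/C(=C(O)/C=C/c2cc(C)cc(C)c2)C(=O)C1(C)C` is reported as < 4 ug/mL, which is a limit of the assay and not a number. Compound 2 `CCCC1=C(OC)C(CCC)(CCC)C(=O)/C(=C(O)\C=C\c2ccccc2)C1=O` is reported as < 4 ug/mL, which is also a limit. Among the measured compounds shown here, compound 2 therefore has no exact value, and the one further value shown for the series is a limit too: the limit of < 4 ug/mL in this assay, at which 2 of the 2 values shown sit. The next step leads to compound 3 `CCCC1=C(OC)C(CCC)(CCC)C(=O)/C(=C(O)\C=C\c2ccc(Br)cc2)C1=O`, with phenyl going to 4-bromophenyl: bromo in place of hydrogen on an aromatic carbon. That is bromo in place of hydrogen on an aromatic carbon, para to a large group. For the measured compounds named here, no measured pair gives a size for such a change, so no step beyond the usual scatter is expected and the direction stays open. The expected step runs a step that the limit leaves unreadable from compound 2 to compound 3. For compound 3 the estimated value is 2 ug/mL, within an expected range of 0.5 ug/mL to 5 ug/mL.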

Compound 3, concentration for half-maximal effect: < 4 ug/mL
Compound 3: no number, only a limit (the forecaster's own chance of this, stated with the estimate: 65%); the middle value does not contradict the limit.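

Compound 3, like compound 2, is reported only as a limit of the assay, so no step can be read for bromo in place of hydrogen on an aromatic carbon: the limit of < 4 ug/mL in this assay, at which 3 of the 3 values shown sit.

The compounds shown leave open whether phenyl to 4-bromophenyl shifts the concentration needed at all, and in which direction.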